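Swapping the Phenolic Aryl Group for a Styryl Chain

The source may report more compounds than this note shows. Statements on the series, on what has been measured and on what is new or still open speak of the compounds shown alone.

Three measured compounds share a five-membered non-aromatic ring that carries an acetyl group. Compound 1 `CC(=O)N1N=C(c2ccco2)CC1c1ccc([N+](=O)[O-])cc1` gives 21300 nM in a functional assay on PC-3 cells (Homo sapiens) for cytotoxicity, read by sulforhodamine B assay, with a stated time of 48 h; a higher number here means a weaker inhibitor, a lower number a stronger inhibitor. Compound 2 `COc1ccc(C2CC(c3cccc4ccccc34)=NN2C(C)=O)cc1OC` gives 2010 nM in this assay, and compound 3 `COc1cc(C2CC(c3cccc4ccccc34)=NN2C(C)=O)ccc1O` gives 2130 nM. Among the compounds with values here, the only single-point step among them is a 1.1-fold higher number from compound 2 to compound 3 (0.03 log units; within the scatter). Compound 3 thus stands second highest of the three numbers, with compound 2 nearest and within the scatter, and compound 1 furthest away, its number higher by more than the scatter.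

Compound 4 `CC(=O)N1N=C(c2cccc3ccccc23)CC1/C=C/c1ccccc1` has not yet been measured in this assay. It differs from compound 3 by 2-phenylethenyl in place of 4-hydroxy-3-methoxyphenyl on a saturated ring carbon. Within the data shown here, no measured step bears directly on this exchange: the step from compound 2 to compound 3 changed only a methyl on an oxygen, and compound 1 differs from the others in two places at once. The expectation therefore rests on the values of compounds 2 and 3 alone. Compound 4 is expected to give about 3000 nM, within a range from 1000 nM to 10000 nM. That estimate means a step of a 1.4-fold higher number from compound 3 to compound 4 (0.15 log units; within the scatter), no change beyond the scatter, though the wide range leaves either direction open.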

Compound 4, half-maximal inhibitory concentration: 21100 nM
Estimate against measurement, compound 4: 7.0-fold (0.85 log units) below; the measured number lies above the stated range.
By their numbers in this assay, from the lowest: compounds 2 and 3 (each within the scatter of the next); then compounds 4 and 1 (each within the scatter of the next).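

Within this assay, the exchange of 4-hydroxy-3-methoxyphenyl for 2-phenylethenyl on the saturated ring carbon gives a 9.9-fold higher number from compound 3 to compound 4 (1.00 log units; beyond the scatter) and so shows that the group at this place can move the number beyond the scatter. The earlier step, a 1.1-fold higher number from compound 2 to compound 3 (0.03 log units; within the scatter), touched only a methyl on an oxygen of that aryl group and stayed within the scatter, so it gave no sign of this. No measurement is at hand to explain why the whole-group exchange matters here.

The compounds shown leave open whether the step follows the double bond outside the aromatic rings or the absence of the hydroxy and methoxy groups. A plain phenyl group, a saturated 2-phenylethyl chain or a 2-phenylethenyl group bearing hydroxy and methoxy on its ring would be needed at this place to separate the two.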